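Replacing phenyl with methyl on the shared core

The source may report more compounds than this note shows. Statements on the series, on what has been measured and on what is new or still open speak of the compounds shown alone.

Measured in a functional assay on MCF7 cells (Homo sapiens) for inhibition, read by sulforhodamine B assay, with a stated time of 48 h; a lower number here means a stronger inhibitor of growth, a higher number a weaker inhibitor of growth:
- compound 1 `c1ccc(-c2ccc(NC3=NCCO3)cc2)cc1`: 10600 nM
- compound 2 `c1cc(OC2CCCCCC2)ccc1NC1=NCCO1`: 26800 nM

Compound 1 has the lower of the two numbers in this assay, and the gap to compound 2 lies beyond the usual scatter. It is therefore the stronger growth inhibitor of this small pair, though both values are high.

The next compound, compound 3 `Cc1ccc(NC2=NCCO2)cc1`, has methyl in place of phenyl on an aromatic carbon, otherwise keeping the core of compound 1. The counted difference is methyl in place of phenyl on an aromatic carbon.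

Among the measured compounds shown here, no step between measured compounds is available, so the size of this change has no direct precedent. For the measured compounds named here, neither measured compound carries a group as small as methyl, and the only anchors are compound 1 at 10600 nM and compound 2 at 26800 nM. A loss of growth inhibition beyond the scatter is expected, though this expectation is weakly supported. The expected change is a 3.8-fold higher number from compound 1 to compound 3 (0.58 log units; beyond the scatter). The estimated value for compound 3 is 40000 nM, with an expected range of 15000 nM to 100000 nM.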

Compound 3, concentration for 50% growth inhibition: 27000 nM
For compound 3 the middle estimate is 1.5-fold (0.17 log units) above the measured one, and the stated range covers the measured number.
By their numbers in this assay, from the lowest: compound 1; then compounds 2 and 3 (each within the scatter of the next).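

In this assay, among the compounds shown here, methyl in place of phenyl on an aromatic carbon gives a 2.5-fold higher number from compound 1 to compound 3 (0.41 log units; beyond the scatter), the first direct reading of a single change at this position and a sign that the substituent there affects the number, though only modestly. Compound 3 reads 27000 nM and compound 2 reads 26800 nM, values within the scatter of each other, so methyl and the larger ether substituent of compound 2 cannot be told apart here, and only the phenyl of compound 1 stands apart from both. No measurement at hand accounts for this difference between phenyl and methyl.

For the compounds shown here, the single step leaves open whether the aromatic ring itself matters or whether any larger carbon group would serve as well, and a longer alkyl chain or a benzyl group on the same aromatic carbon would help separate these readings. Going by these compounds, how an amine or a carboxylic acid at this position would read in this assay also remains open, as does whether any change here could bring the number far below the high values seen so far.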